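Benzyl selenium analogue of compound 1 in the cytotoxicity read-out

The compounds below may be only part of what the source reports. "The series", "measured", "known", "first", "only" and "open" are said of these compounds alone.

Among the compounds with values here, the three measured members share a selenourea-type linker bearing two acyl arms and differ in the acyl group and in the substituent on the selenium. Compound 1 `C[Se]/C(=N\C(=O)c1cc2ccccc2s1)NC(=O)c1cc2ccccc2s1` carries a methyl on selenium; in a functional assay on MCF7 cells (Homo sapiens) for cytotoxicity, read by MTT assay, with a stated time of 72 h (on this read-out lower numbers stand for higher toxicity in this test and higher numbers for lower toxicity in this test), compound 1 gives 80600 nM. Compound 2 `O=C(/N=C(/NC(=O)c1cc(-c2ccccc2)nc2ccccc12)[Se]Cc1ccccc1)c1cc(-c2ccccc2)nc2ccccc12` and compound 3 `O=C(/N=C(/NC(=O)c1csc([N+](=O)[O-])c1)[Se]Cc1ccccc1)c1csc([N+](=O)[O-])c1` each carry a benzyl on selenium with other acyl arms; in this assay compound 2 gives 97000 nM, and in this assay compound 3 gives 83800 nM. Compound 1 holds the lowest of the three numbers, yet its gap to compound 3 and its gap to compound 2 both lie within the usual scatter, so the three cannot be ordered.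

Compound 4 `O=C(/N=C(/NC(=O)c1cc2ccccc2s1)[Se]Cc1ccccc1)c1cc2ccccc2s1` keeps the acyl arms of compound 1 and differs from it only by phenyl in place of hydrogen on a saturated chain carbon bound to a selenium atom. Since the two benzyl compounds 2 and 3 sit at the same level as compound 1 in this assay, no step beyond the scatter is expected from compound 1 to compound 4; the step of a 1.1-fold higher number from compound 1 to compound 4 (0.02 log units; within the scatter) is estimated to be essentially flat. Compound 4 is thus expected to give 85000 nM in this assay, with a range from 40000 nM to 180000 nM.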

Compound 4, concentration lethal to 50% of the cells: 87900 nM
Compound 4: the middle estimate sits 1.0-fold (0.01 log units) below what was measured; the range from low to high includes it.
By their numbers in this assay, from the lowest: compounds 1, 3, 4 and 2 (each within the scatter of the next).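

Within the data shown here, the pair of compound 1 and compound 4 is the first comparison in which the acyl arms are held constant, so the substituent on selenium can be read on its own; the earlier benzyl compounds also carried other acyl arms. In this assay the change from methyl to benzyl, with phenyl in place of hydrogen on a saturated chain carbon bound to a selenium atom, gives a 1.1-fold higher number from compound 1 to compound 4 (0.04 log units; within the scatter) and so does not separate the two compounds on this read-out, at least with these acyl arms. No supporting measurement on these compounds bears on this flat step.

On these data alone, it remains open whether a group of another kind on that carbon, such as an amine, a carboxylic acid or a longer chain, would give a step beyond the scatter. The compounds shown also leave open whether the methyl to benzyl change stays as flat with other acyl arms, since this single pair is the only direct comparison at this position.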